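Pyridinylamide replaces pyrrolidine amide in a chromanone-free core series

A few compounds are considered here, and "the series" means these few. Any claim that something is new, unique, unknown or untested is made for them only; others in the source may bear on it.

Of the compounds shown here, two sharing one core have been measured so far. Compound 1 `Cc1c(C)c2c(c(C)c1O)CCC(C)(C(=O)N1CCN(c3ncccn3)CC1)O2` gives 23000 nM in a functional assay (brain) for inhibition, with Rattus norvegicus as the target; on this read-out higher numbers stand for weaker inhibition and lower numbers for stronger inhibition. Compound 2 `Cc1c(C)c2c(c(C)c1O)CCC(C)(C(=O)N1CCCC1)O2` gives 10000 nM in this assay, the lower of the two numbers; the gap to compound 1 lies beyond the usual scatter of repeated measurements, so compound 2 is the stronger inhibitor of the two by a modest margin. For the measured compounds named here, no step between two compounds differing in only one place has been measured.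

Compound 3 `Cc1c(C)c2c(c(C)c1O)CCC(C)(C(=O)Nc1ccncc1)O2` has not yet been measured in this assay. It differs from compound 2 in one place: (pyridin-4-yl)amino in place of pyrrolidin-1-yl on a carbonyl carbon. Since no comparable change has been measured, the expectation for compound 3 rests only on the weak inhibition shown by compound 2 at 10000 nM and by compound 1 at 23000 nM. The step of a 1.4-fold higher number from compound 2 to compound 3 (0.15 log units; within the scatter) is expected to stay within the scatter, with no clear direction. Compound 3 is therefore estimated at 14000 nM, with a plausible range from 4000 nM to 50000 nM.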

Compound 3, half-maximal inhibitory concentration: 2300 nM
Compound 3: middle estimate off by 6.1-fold (0.78 log units), on the high side, outside the stated range (below it).
By their numbers in this assay, from the lowest: compound 3; then compound 2; then compound 1.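

In this assay, for the compounds shown here, the group on the carbonyl carbon turns out to matter: a 4.3-fold lower number from compound 2 to compound 3 (0.64 log units; beyond the scatter), the first step measured between compounds that differ in one place, and it lies beyond the usual scatter. The change swaps pyrrolidin-1-yl, a five-membered non-aromatic ring with no hydrogen-bond donor or acceptor, for (pyridin-4-yl)amino, a six-membered aromatic ring group that brings one of each, and the direction is towards stronger inhibition, so this position tolerates an aromatic group and gains from this one. No measurement shown here explains the gain, and the step alone cannot say which feature of the new group is responsible.

The compounds shown leave open whether the amide hydrogen, the aromatic ring or the pyridine nitrogen carries the step, since all three enter together. A phenylamino group would test the ring without the pyridine nitrogen, a pyridin-3-ylamino group would test where that nitrogen sits, and a piperidin-1-yl group would test a six-membered ring that is neither aromatic nor carries an amide hydrogen.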